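Working notes: para-methoxy removal and tolerance in one series

The source may report more compounds than this note shows. Statements on the series, on what has been measured and on what is new or still open speak of the compounds shown alone.

All three measured compounds were tested in an ADME assay on Vero cells (Chlorocebus sabaeus) for inhibition; a higher number here means that more compound is tolerated, a lower number that less compound is tolerated:
compound 1 `COc1ccc(/C=C2\CCC/C(=C\c3ccc(OC)cc3)C2=O)cc1` gives 178000 nM
compound 2 `COc1ccc(/C=C2\CCC/C(=C\c3ccccc3)C2=O)cc1` gives 291000 nM
compound 3 `COc1ccc(/C=C2\CCC/C(=C\c3cccc(OC)c3OC)C2=O)cc1` gives 401000 nM

The step of a 1.6-fold higher number from compound 1 to compound 2 (0.21 log units; within the scatter) goes with hydrogen in place of methoxy on an aromatic carbon. Compound 3 gives the highest number of the three; against compound 2 the gap lies within the scatter, against compound 1 it lies beyond it. The difference between the core of compound 1 and the core of compound 3 is not broken down here.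

Compound 4 `COc1cccc(/C=C2\CCC/C(=C\c3ccccc3)C2=O)c1OC` has not yet been measured in this assay. It differs from compound 3 by hydrogen in place of methoxy on an aromatic carbon, the same change, at the same place, as that between compound 1 and compound 2; the change occurs twice among the compounds shown. The expected step is a 1.2-fold higher number from compound 3 to compound 4 (0.10 log units; within the scatter), set beside a 1.6-fold higher number from compound 1 to compound 2 (0.21 log units; within the scatter), which stayed within the scatter, with nothing in the data pointing to a different outcome on the core of compound 3. For compound 4 the estimated value is 500000 nM, with a range from 250000 nM to 1000000 nM.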

Compound 4, half-maximal cytotoxic concentration: 33500 nM
For compound 4 the middle estimate is 15-fold (1.17 log units) above the measured one; the whole stated range lies above it.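

In this assay, hydrogen in place of methoxy, read as 4-methoxyphenyl to phenyl, gives a 12-fold lower number from compound 3 to compound 4 (1.08 log units; beyond the scatter). The change therefore does not carry over as a constant step between these two cores: the same change on two cores in this assay, a 1.6-fold higher number (0.21 log units; within the scatter) from compound 1 to compound 2 and a 12-fold lower number (1.08 log units; beyond the scatter) from compound 3 to compound 4, 20-fold (1.29 log units) apart, beyond the scatter of two such steps. Among these compounds, this shows that the step seen on the core of compound 1 cannot be transferred to the core of compound 3 in this series, but only one pair stands on each core, so it does not show which feature of the core of compound 3 sets the difference, nor how the step would run on any further core.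

The compounds shown leave open whether other replacements at the same place, such as a hydroxyl, an amine or a carboxylic acid, would give a small step on both cores or a large one on the core of compound 3 alone. Also open, from the compounds shown here alone, is whether a longer chain there, such as ethoxy in place of methoxy, would keep the number of compound 3.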